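This account rests on a few compounds, and the source may have more. Where it says the series, first, only, none or still open, it means among the compounds named here.

Working notes on the series. The shared core carries on an aromatic carbon a group that decides the outcome. Going by the values given here, compound 2 `COC(=O)c1ccccc1-c1ccc(CNc2nccc(C)c2NC(=O)CC#N)cc1` is the only member with a number: in an assay on isolated protein for binding affinity to B1 bradykinin receptor (Homo sapiens) (on this read-out higher numbers stand for weaker inhibition and lower numbers for stronger inhibition), compound 2 gives 11 nM. Compound 1 `COC(=O)N1CCCCC1c1ccc(CNc2nccc(C)c2NC(=O)CC#N)cc1` returns only a limit in this assay, > 5000 nM. Among the compounds with values here, that limit, (the limit of > 5000 nM in this assay, at which 1 of the 2 values shown sits), frames the single step, an at least 450-fold lower number from compound 1 to compound 2 (2.65 log units; beyond the scatter), in which 2-(methoxycarbonyl)phenyl in place of 1-(methoxycarbonyl)piperidin-2-yl on an aromatic carbon drove the number far down. Compound 3 `COC(=O)C1CCCN1c1ccc(CNc2nccc(C)c2NC(=O)CC#N)cc1` is not yet measured; it differs from compound 2 by 2-(methoxycarbonyl)pyrrolidin-1-yl in place of 2-(methoxycarbonyl)phenyl on an aromatic carbon. Within the data shown here, this again removes the aromatic ring of the 2-(methoxycarbonyl)phenyl and sets a non-aromatic ring bearing an ester in its place, so the one measured step points toward a large rise in this assay. Compound 3 is therefore expected to give 2000 nM, within 300 nM to 8000 nM. The expected step is a 180-fold higher number from compound 2 to compound 3 (2.26 log units; beyond the scatter), with a real chance that only a limit is reported.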

Compound 3, inhibition constant: > 5000 nM
Compound 3: only a limit was reported; the forecaster's own chance of this, stated with the estimate: 45%; middle value at least 2.5-fold (0.39 log units) away from the limit.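

Replacing 2-(methoxycarbonyl)phenyl with 2-(methoxycarbonyl)pyrrolidin-1-yl gives an at least 450-fold higher number from compound 2 to compound 3 (2.65 log units; beyond the scatter) in this assay. The large loss is therefore not tied to the 1-(methoxycarbonyl)piperidin-2-yl group of compound 1: it recurs with a five-membered non-aromatic ring, and of the compounds shown, only compound 2, with its six-membered aromatic ring of carbon only, gives a number rather than a limit. The step between compound 1 and compound 3 cannot be read, so no order can be given between the two non-aromatic groups, since both compounds sit at the same limit: the limit of > 5000 nM in this assay, at which 2 of the 3 values shown sit.

Going by these compounds, it remains open whether the number in compound 2 depends on the aromatic ring alone or also on its ester. A plain phenyl, or a phenyl carrying a carboxylic acid or a primary amide in place of the methyl ester, would separate these two contributions.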